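Naphthalene to Tolyl in a Series Sitting at the Limit

A few compounds are considered here, and "the series" means these few. Any claim that something is new, unique, unknown or untested is made for them only; others in the source may bear on it.

Compound 1, `CCOC(=O)C1=Cc2ccccc2OC1(OCc1cc(-c2ccc(OC)cc2)no1)C(F)(F)F`: in a functional assay on HeLa cells (Homo sapiens) for inhibition, read by MTT assay, with a stated time of 24 h (a higher number here means a weaker inhibitor, a lower number a stronger inhibitor), compound 1 gives > 150000 nM, which is a limit of the assay and not a number.
Compound 2, `CCOC(=O)C1=Cc2ccccc2OC1(OCc1cn(CC(=O)Nc2cccc(F)c2)nn1)C(F)(F)F`: in this assay compound 2 gives > 150000 nM, again a limit.
Compound 3, `CCOC(=O)C1=Cc2ccccc2OC1(OCc1cc(-c2ccc3ccccc3c2)no1)C(F)(F)F`: in this assay compound 3 gives > 150000 nM, again a limit.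

Within the data shown here, compound 3 therefore stands only at a limit, and the two further values shown are limits as well, so no compound in this set has a measured number at all. Among the measured compounds shown here, the one step between measured compounds that differ in a single place, a step that the two limits leave unreadable from compound 1 to compound 3, cannot be read in size because the limit of > 150000 nM in this assay, at which 3 of the 3 values shown sit, caps both of its ends.

Compound 4, `CCOC(=O)C1=Cc2ccccc2OC1(OCc1cc(-c2ccc(C)cc2)no1)C(F)(F)F`, has not yet been measured. Compared with compound 3 the change is 4-methylphenyl in place of naphthalen-2-yl on an aromatic carbon. For the measured compounds named here, the only measured step that touches this position is the unreadable one above, so nothing here points to a gain or a loss beyond the scatter; all that is known is that three different groups at this position all left the compound at the limit.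

Compound 4 is accordingly expected to give 200000 nM in this assay, with a range from 100000 nM to 500000 nM. The expected step that the limit leaves unreadable from compound 3 to compound 4 is small, and most likely the assay will once more report only a limit for compound 4.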

Compound 4, half-maximal inhibitory concentration: > 150000 nM
Compound 4 ended at the assay's limit; the forecaster's own chance of this, stated with the estimate: 85%; the middle value is on the limit's open side.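

Compound 4 also stands at a limit and not at a number, so the steps to it from compound 3 and from compound 1 cannot be read in size, because both ends of each step are capped: the limit of > 150000 nM in this assay, at which 4 of the 4 values shown sit.

The compounds shown leave open whether any group at this position, or any other change to the shared core, would give a measurable number in this assay.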